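This account rests on a few compounds, and the source may have more. Where it says the series, first, only, none or still open, it means among the compounds named here.

Of the compounds shown here, three built on one shared core have been measured in an ADME assay on Caco-2 cells (Homo sapiens) for permeability, in the apical to basolateral direction; a lower number here means that the compound crosses the layer more slowly, a higher number that the compound crosses the layer faster. Compound 1 `Cn1cncc1CN1CC(N(CC2CCN(C(=O)c3ccccc3)CC2)S(=O)(=O)c2ccccn2)Cc2cc(C#N)ccc21` gives 0.5 10^-6 cm/s. Compound 2 `Cn1cncc1CN1CC(N(CC2CCN(C(=O)CC(F)(F)F)CC2)S(=O)(=O)c2ccccn2)Cc2cc(C#N)ccc21` gives 0.5 10^-6 cm/s, and compound 3 `CC(C)S(=O)(=O)N1CCC(CN(C2Cc3cc(C#N)ccc3N(Cc3cncn3C)C2)S(=O)(=O)c2ccccn2)CC1` gives 0.1 10^-6 cm/s. Compound 2 thus stands level with compound 1 at the digits shown, the two together being the highest of the three numbers; its nearest neighbour is compound 1, with no change at the digits printed from compound 1 to compound 2 (within the scatter), and its furthest is compound 3, with a 5.0-fold lower number from compound 2 to compound 3 (0.70 log units; beyond the scatter). The third measured step, a 5.0-fold lower number from compound 1 to compound 3 (0.70 log units; beyond the scatter), is likewise a modest lowering.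

Compound 4 `Cn1cncc1CN1CC(N(CC2CCN(C(=O)NC(C)(C)C)CC2)S(=O)(=O)c2ccccn2)Cc2cc(C#N)ccc21` awaits measurement in this assay. It differs from compound 2 in one place: (tert-butyl)amino in place of 2,2,2-trifluoroethyl on a carbonyl carbon. Of the measured steps, only no change at the digits printed from compound 1 to compound 2 (within the scatter) alters the group on that same carbonyl carbon, and it brought no change beyond the scatter. The two steps that did move the number, a 5.0-fold lower number from compound 1 to compound 3 (0.70 log units; beyond the scatter) and a 5.0-fold lower number from compound 2 to compound 3 (0.70 log units; beyond the scatter), alter the group on the ring nitrogen instead and were modest. For the measured compounds named here, no measured step adds a hydrogen-bond donor, so the data give no direct guide for that part of the change. The expected step is therefore small and, if anything, downward: a 1.3-fold lower number from compound 2 to compound 4 (0.10 log units; within the scatter). Compound 4 is estimated at 0.4 10^-6 cm/s, with a range from 0.15 10^-6 cm/s to 1 10^-6 cm/s.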

Compound 4, apparent permeability: 0.6 10^-6 cm/s
Beside the measured number, compound 4's estimate is 1.5-fold (0.18 log units) below it; the measured number falls inside the stated range.
By their numbers in this assay, from the lowest: compound 3; then compounds 1, 2 and 4 (each within the scatter of the next).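

In this assay the group on the carbonyl carbon now reads as a position where even the entry of a hydrogen-bond donor leaves the number within the scatter: there is a 1.2-fold higher number from compound 2 to compound 4 (0.08 log units; within the scatter) and also a 1.2-fold higher number from compound 1 to compound 4 (0.08 log units; within the scatter) in the same way as no change at the digits printed from compound 1 to compound 2 (within the scatter) before it, so (tert-butyl)amino, phenyl and 2,2,2-trifluoroethyl cannot be told apart here. On the ring nitrogen, the result adds a third group to the comparison with isopropylsulfonyl, with a 6.0-fold higher number from compound 3 to compound 4 (0.78 log units; beyond the scatter) and a size like that of the two earlier steps to compound 3, so that (tert-butyl)carbamoyl joins benzoyl and (2,2,2-trifluoroethyl)carbonyl on the far side of the scatter from that sulfonyl group. Nothing measured here gives a reason for either observation.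

Still open, going by these compounds, is whether this carbonyl carbon stays as undemanding with an amine or a carboxylic acid carried on a longer chain, since the three groups compared here include neither of these. On these data alone, it is also open whether the lower number of compound 3 goes with sulfonyl groups on the ring nitrogen in general, for instance methylsulfonyl or phenylsulfonyl, or with isopropylsulfonyl alone.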